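The source may report more compounds than this note shows. Statements on the series, on what has been measured and on what is new or still open speak of the compounds shown alone.

Measured compounds:
- compound 1, `Cn1c(=O)c(S(=O)(=O)c2ccc(F)cc2F)cc2cnc(Nc3ccc4occc4c3)nc21`: 15000 nM
- compound 2, `Cn1c(=O)c(S(=O)(=O)c2ccc([N+](=O)[O-])cc2F)cc2cnc(Nc3ccc4[nH]ccc4c3)nc21`: 200 nM
- compound 3, `COC(=O)Cn1ccc2cc(Nc3ncc4cc(S(=O)(=O)c5ccc(F)cc5F)c(=O)n(C)c4n3)ccc21`: 5000 nM

All three were run in a functional assay on K562 cells (Homo sapiens) for inhibition, read by trypan blue exclusion, with a stated time of 72 h; on this read-out higher numbers stand for weaker inhibition and lower numbers for stronger inhibition. Compound 2 gives the lowest number of the three; its nearest neighbour is compound 3, which gives 5000 nM, a gap beyond the scatter, and the furthest is compound 1 with 15000 nM, also beyond the scatter. Compound 2 therefore stands alone as the most potent of the measured set. For the measured compounds named here, the three measured compounds each differ in more than one place, so no single step between them can be read off.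

The next compound, compound 4, `COc1ccc(S(=O)(=O)c2cc3cnc(Nc4ccc5[nH]ccc5c4)nc3n(C)c2=O)cc1`, is built from compound 2 by one change: 4-methoxyphenyl in place of 2-fluoro-4-nitrophenyl on a sulfonyl sulfur. The core and the indole-bearing aryl amine are kept. Nothing in the measured set isolates the effect of this replacement, since the other sulfonyl aryl groups occur only together with other changes. The expectation is a moderate loss of potency, with the step of a 5.0-fold higher number from compound 2 to compound 4 (0.70 log units; beyond the scatter) expected to lie beyond the scatter. For compound 4 the estimate in this assay is 1000 nM, within a range from 300 nM to 4000 nM.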

Compound 4, half-maximal inhibitory concentration: 300 nM
Estimate against measurement, compound 4: 3.3-fold (0.52 log units) above; the range from low to high includes it.
By their numbers in this assay, from the lowest: compounds 2 and 4 (each within the scatter of the next); then compound 3; then compound 1.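

In this assay, for the compounds shown here, placing 4-methoxyphenyl in place of 2-fluoro-4-nitrophenyl on a sulfonyl sulfur gives a 1.5-fold higher number from compound 2 to compound 4 (0.18 log units; within the scatter), the first comparison that differs in one place only. With the rest of the structure kept, this aryl position therefore takes either group without a change beyond the scatter, so neither the fluorine nor the nitro group is required for a value at this level in this pair. No measurement at hand accounts for this result.

Going by these compounds, whether the sulfonyl sulfur can carry an aryl group bearing an amine or a carboxylic acid, or a simple methyl group instead of an aryl ring, remains open. The steps linking compound 1 and compound 3 to the others cannot be read, since each differs from them in more than one place.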